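The source may report more compounds than this note shows. Statements on the series, on what has been measured and on what is new or still open speak of the compounds shown alone.

Compound 1 `COc1ccc(C2=NN(c3nc(-c4ccc(C(F)(F)F)cc4)cs3)C(c3cccs3)C2)cc1`: 8110 nM
Compound 2 `Brc1ccc(C2=NN(c3nc(-c4ccccc4)cs3)C(c3cccs3)C2)cc1`: 1870 nM

Among the measured compounds shown here, in a functional assay on WM 266-4 cells (Homo sapiens) for antiproliferative activity, read by MTT assay, with a stated time of 48 h (a lower number here means a stronger inhibitor, a higher number a weaker inhibitor), compound 2 gives 1870 nM, the lower of the two numbers measured so far, while compound 1 gives 8110 nM, a higher number. The two compounds differ from each other in more than one place, so the gap between them cannot be assigned to any single change. Compound 3 `FC(F)(F)c1ccc(-c2csc(N3N=C(c4ccc(Br)cc4)CC3c3cccs3)n2)cc1` keeps everything of compound 2 except one site: trifluoromethyl in place of hydrogen on an aromatic carbon. Compound 1 already carries the trifluoromethyl group that enters here, yet it also differs from compound 2 elsewhere, so its higher number is not a clean guide. For the measured compounds named here, with only two measured points and no matched pair for this change, a step of moderate size in either direction is possible, and the expectation is a step not clearly beyond the scatter, a 1.3-fold higher number from compound 2 to compound 3 (0.13 log units; within the scatter). For compound 3 in this assay the estimated value is 2500 nM, within a range from 900 nM to 7000 nM.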

Compound 3, half-maximal inhibitory concentration: 27400 nM
Compound 3: the middle estimate sits 11-fold (1.04 log units) below what was measured, outside the stated range (above it).
By their numbers in this assay, from the lowest: compound 2; then compound 1; then compound 3.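

In this assay, among the compounds shown here, the first clean comparison at this site shows that trifluoromethyl in place of hydrogen, para to a large group on the six-membered aromatic ring, gives a 15-fold higher number from compound 2 to compound 3 (1.17 log units; beyond the scatter) and so a large loss of activity against these cells. With trifluoromethyl kept in place, bromo in place of methoxy on an aromatic carbon gives a 3.4-fold higher number from compound 1 to compound 3 (0.53 log units; beyond the scatter) and so a modest further change at a second site, with the methoxy compound the stronger of this pair. No supporting measurement bears on why either step occurs.

Going by these compounds, whether the loss is specific to trifluoromethyl or would also appear with a fluorine atom, a methyl group or an amine at the same place stays open. So does whether trifluoromethyl has the same effect when methoxy replaces bromo.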